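Phenyl in place of ethoxycarbonyl: notes toward compound 4

A few compounds are considered here, and "the series" means these few. Any claim that something is new, unique, unknown or untested is made for them only; others in the source may bear on it.

The series is followed in an assay on isolated protein for inhibition of glucose-6-phosphatase catalytic subunit 1 (Homo sapiens), read by inositol phosphate accumulation, with a stated time of 30 min, tested at 100 uM; a lower number here means less inhibition, a higher number more inhibition at the concentration tested (going by the name of the read-out). Compound 2 `CCOC(=O)C1=CC(c2ccccc2)C2=C(CC(C)(C)CC2=O)N1` is the starting point here; in this assay compound 2 is recorded as "not active" (no number reported), with no number attached. Compound 1 `CCOC(=O)C1=CC(c2ccc(Br)cc2)C2=C(CC(C)(C)CC2=O)N1` carries a bromine on its phenyl ring where the phenyl ring of compound 2 carries none; in this assay compound 1 is likewise recorded as "not active" (no number reported). Compound 3 `CC1(C)CC(=O)c2c(-c3ccc(F)cc3)cc(-c3ccccc3)nc2C1`, built on a different core with two aromatic substituents, gives 11.1% in this assay, a figure that sits within the usual scatter of no inhibition at all. Compound 2 therefore stands among entries that show nothing measurable in this assay.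

The step to compound 4 `CC1(C)CC(=O)C2=C(C1)NC(c1ccccc1)=CC2c1ccccc1` is phenyl in place of ethoxycarbonyl on a double-bonded ring carbon. Phenyl replaces ethoxycarbonyl; the core of compound 2 is kept. Among the compounds with values here, no measured pair of this kind exists in the set, so the size of the step is a guess: no move in this assay beyond the scatter is expected in either direction, since compound 1 and compound 2 both sit without a number and compound 3 with its two aromatic substituents sits low. Compound 4 is accordingly expected to give about 8% in this assay, within 0% to 22%, and quite possibly to be reported with no number at all.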

Compound 4, a percentage reported as inhibition, at one concentration (the size of the read-out at that concentration, not a potency): "not active" (no number reported)
Nothing numeric was reported for compound 4, and the estimate cannot be compared.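

No step can be read from compound 2 to compound 4: both stand without a number in this assay. No evidence at hand bears on this result. The compounds shown leave open whether phenyl in place of ethoxycarbonyl changes inhibition at all.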